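Branched Alkyl Replaces Aryl on a Bombesin Receptor Agonist

The source may report more compounds than this note shows. Statements on the series, on what has been measured and on what is new or still open speak of the compounds shown alone.

Two compounds share a core in which an imidazole is joined through a two-carbon linker to a biphenyl carboxylic acid. Compound 1 `CCC(C)(C)Cc1c[nH]c(CCc2ccc(-c3ccccc3C(=O)O)cc2)n1` carries a branched alkyl substituent and, in an in vitro functional assay on cells for agonist activity at Bombesin receptor subtype-3 (Mus musculus), read by luminescence and calcium flux (on this read-out lower numbers stand for an effect already at smaller amounts and higher numbers for an effect only at larger amounts of compound), compound 1 gives 9.6 nM. Compound 2 `Cc1cccc(Cc2cnc(CCc3ccc(-c4ccccc4C(=O)O)cc3)[nH]2)c1` carries a 3-methylbenzyl group instead, and in this assay compound 2 gives 75 nM. Of these two numbers compound 2 has the higher one, and the gap to compound 1 lies beyond the usual scatter.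

Compound 3 `CCC(C)(CC)Cc1cnc(CCc2ccc(-c3ccccc3C(=O)O)cc2)[nH]1` is not yet measured. It differs from compound 2 as follows: 1-ethyl-1-methylpropyl in place of 3-methylphenyl on a saturated chain carbon bound to an aromatic carbon. The group entering closely resembles the branched alkyl chain of compound 1, differing from it only in the length of one branch.

Since compound 1 with its branched alkyl gives 9.6 nM, compound 3 is expected to move toward that value rather than stay at the level of compound 2. The step from compound 2 to compound 3 in this assay is estimated as a 6.3-fold lower number from compound 2 to compound 3 (0.80 log units; beyond the scatter), a decrease beyond the scatter. Compound 3 is therefore expected to give about 12 nM, with a plausible range from 4 nM to 40 nM.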

Compound 3, half-maximal effective concentration: 30 nM
The estimate for compound 3 lay 2.5-fold (0.40 log units) below the measured number; low and high end bracket the measured number.
By their numbers in this assay, from the lowest: compound 1; then compound 3; then compound 2.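

Within the data shown here, putting 1-ethyl-1-methylpropyl in place of 3-methylphenyl, on a saturated chain carbon bound to an aromatic carbon, gives a 2.5-fold lower number from compound 2 to compound 3 (0.40 log units; beyond the scatter) in this assay, a modest gain that is the first direct comparison at this position with only one place changed. It shows that the six-membered aromatic ring of compound 2 is not needed for agonist activity at this position, since an all-carbon branched group with no ring gives a lower number, although compound 3 still lies above compound 1 at 9.6 nM. The compounds shown offer no measurement that explains why this change lowers the number.

Still open, from the compounds shown here alone, is whether it is the removal of the ring or the branching of the group entering that matters, and a cyclohexyl ring in place of 3-methylphenyl would help separate the two by keeping a ring that is not aromatic. It is also unclear how far this position tolerates other changes, such as a longer unbranched chain like n-hexyl, or an amine or a hydroxyl group placed on the branched chain.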